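The source may hold more compounds than are shown below. What is called first, only, known or untested is meant among the compounds shown, and "the series" means these compounds.

In a functional assay on HeLa cells (Homo sapiens) for cytotoxicity, read by MTT assay, with a stated time of 48 h (a lower number here means that less compound is needed, a higher number that more compound is needed for the effect), compound 1 (`CSc1ccc(/C=N/n2c(Cc3ccc(S(C)(=O)=O)cc3)n[nH]c2=S)cc1`) gives 50000 nM. Compound 2 (`CS(=O)(=O)c1ccc(Cc2n[nH]c(=S)n2/N=C/c2cccnc2)cc1`) reads > 100000 nM, which is a limit and not a number. Compound 2 therefore stands at the limit of > 100000 nM in this assay, at which 1 of the 2 values shown sits. Within the data shown here, the only measured step is an at least 2.0-fold higher number from compound 1 to compound 2 (0.30 log units; that floor lies within the scatter). Compound 3 (`CS(=O)(=O)c1ccc(Cc2n[nH]c(=S)n2/N=C/c2ccc(Cl)cc2)cc1`) carries 4-chlorophenyl in place of pyridin-3-yl on a carbon with a double bond to nitrogen. Its ring is again carbon only, as in compound 1 with 50000 nM, so a modest move to a lower number is expected in this assay. The expected step is an at least 2.0-fold lower number from compound 2 to compound 3 (0.30 log units; that floor lies within the scatter). The estimate for compound 3 is 50000 nM, ranging from 20000 nM to 120000 nM.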

Compound 3, half-maximal effective concentration: 50000 nM
Compound 3: middle estimate and measured number agree at the digits printed, within the range that was stated.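

In this assay, 4-chlorophenyl in place of pyridin-3-yl gives an at least 2.0-fold lower number from compound 2 to compound 3 (0.30 log units; that floor lies within the scatter). Compound 2 reads only as a limit, so this step is a floor and not a measured size: the limit of > 100000 nM in this assay, at which 1 of the 3 values shown sits. Chloro in place of methylsulfanyl on the aromatic carbon gives no change at the digits printed from compound 1 to compound 3 (within the scatter), so these two groups on a ring of carbon only do not separate here.

As far as these compounds go, whether an amine or a carboxylic acid on that aromatic carbon would read differently stays open. From the compounds shown here alone, how far compound 2 truly lies from compound 3 also stays open.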